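Chain on the ring nitrogen: from compound 2 to compound 3

The source may report more compounds than this note shows. Statements on the series, on what has been measured and on what is new or still open speak of the compounds shown alone.

Measured so far:
compound 1 `COc1cc(Cc2nc3c(N)ncnc3n2CC2CC2)cc(OC)c1OC` — 75900 nM
compound 2 `CCCn1c(Cc2cc(OC)c(OC)c(OC)c2)nc2c(N)ncnc21` — 46800 nM

Going by the values given here, only two numbers exist in a functional assay on MCF7 cells (Homo sapiens) for antiproliferative activity (a higher number here means a weaker inhibitor, a lower number a stronger inhibitor), and compound 2 stands within the scatter of compound 1; the margin is a 1.6-fold lower number from compound 1 to compound 2 (0.21 log units; within the scatter) and separates nothing. Compound 3 `COCCn1c(Cc2cc(OC)c(OC)c(OC)c2)nc2c(N)ncnc21` differs from compound 2 by methoxy in place of methyl on a saturated chain carbon, two bonds along the chain from an aromatic nitrogen. Among the compounds with values here, the single measured step, a 1.6-fold lower number from compound 1 to compound 2 (0.21 log units; within the scatter), also alters the chain on the aromatic nitrogen, ethyl in place of cyclopropyl on the chain carbon bound to that nitrogen, and it stayed within the scatter. Within the data shown here, no measured step puts an oxygen into this chain, so the change in compound 3 has no direct precedent. On what is known, the expected step of a 1.1-fold higher number from compound 2 to compound 3 (0.03 log units; within the scatter) is none beyond the scatter. Compound 3 is accordingly estimated at 50000 nM in this assay, with a range from 18000 nM to 140000 nM.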

Compound 3, half-maximal inhibitory concentration: 64600 nM
Beside the measured number, compound 3's estimate is 1.3-fold (0.11 log units) below it; low and high end bracket the measured number.
By their numbers in this assay, from the lowest: compounds 2, 3 and 1 (each within the scatter of the next).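

In this assay, an oxygen in the chain on the aromatic nitrogen does not separate the compounds: methoxy in place of methyl, two bonds along the chain from an aromatic nitrogen, gives a 1.4-fold higher number from compound 2 to compound 3 (0.14 log units; within the scatter) and stays within the scatter. Methoxymethyl in place of cyclopropyl on the saturated chain carbon bound to that nitrogen gives a 1.2-fold lower number from compound 1 to compound 3 (0.07 log units; within the scatter) and also stays within the scatter, so the three chains shown cannot be told apart at this position. No evidence is available to account for this result.

On these data alone, whether any group on this chain can move the number beyond the scatter remains open, for example an amine or a carboxylic acid at the chain end, or a longer chain. Equally open, as far as these compounds go, is whether changes elsewhere on the shared core would do so.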